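This account rests on a few compounds, and the source may have more. Where it says the series, first, only, none or still open, it means among the compounds named here.

Measured so far in a functional assay on MCF7 cells (Homo sapiens) for antiproliferative activity, read by MTT assay, with stated times of 24 h and 72 h; a higher number here means a weaker inhibitor, a lower number a stronger inhibitor

- compound 1 `COc1cc(N2C(=O)[C@@H](Oc3ccccc3)[C@H]2c2ccc(C#N)cc2)cc(OC)c1OC` gives 31600 nM
- compound 2 `COc1cc(N2C(=O)[C@@H](Oc3ccccc3)[C@H]2c2ccc([S+](C)[O-])cc2)cc(OC)c1OC` gives 20000 nM
- compound 3 `COc1cc(N2C(=O)[C@@H](Oc3ccccc3)[C@H]2c2ccc(O)cc2)cc(OC)c1OC` gives 48000 nM

Compound 3 has the 4-hydroxyphenyl group on the shared core. Its number lies within the scatter of the value for compound 1, as the step of a 1.5-fold higher number from compound 1 to compound 3 (0.18 log units; within the scatter) shows. Only the gap to compound 2 goes past the scatter, and modestly so: a 2.4-fold higher number from compound 2 to compound 3 (0.38 log units; beyond the scatter).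

The next compound keeps the same atoms and moves the hydroxy group. For compound 4 `COc1cc(N2C(=O)[C@@H](Oc3ccccc3)[C@H]2c2cccc(O)c2)cc(OC)c1OC` the change is 3-hydroxyphenyl in place of 4-hydroxyphenyl on a saturated ring carbon.

Within the data shown here, no measured step tests such a move directly. The nearest evidence is the set of swaps of the group on this same aryl ring. These are a 1.6-fold lower number from compound 1 to compound 2 (0.20 log units; within the scatter) and the two steps above, and the largest of them is the modest one from compound 2. Going by these compounds, the series has so far responded weakly to changes at this ring, though three compounds are a thin basis, and the new placement of the hydroxy group is untested.

A slightly lower number is therefore expected, with no step beyond the scatter. The expected step is a 1.6-fold lower number from compound 3 to compound 4 (0.20 log units; within the scatter). The estimated value for compound 4 is 30000 nM, with an expected range from 11000 nM to 70000 nM.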

Compound 4, half-maximal inhibitory concentration: 54000 nM
Estimate against measurement, compound 4: 1.8-fold (0.26 log units) below; measured number inside the range.
By their numbers in this assay, from the lowest: compounds 2, 1, 3 and 4 (each within the scatter of the next, the first and the last beyond it).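

In this assay, 3-hydroxyphenyl in place of 4-hydroxyphenyl on the saturated ring carbon gives a 1.1-fold higher number from compound 3 to compound 4 (0.05 log units; within the scatter), so this first direct test of the hydroxy placement does not separate the two isomers. Compound 4 also cannot be separated from the nitrile-bearing compound, with a 1.7-fold higher number from compound 1 to compound 4 (0.23 log units; within the scatter), whereas a 2.7-fold higher number from compound 2 to compound 4 (0.43 log units; beyond the scatter) places both hydroxy isomers beyond the scatter of the sulfur-bearing compound 2, since compound 3 shows the same kind of modest gap. No supporting measurement is available to account for these values.

The aryl groups shown carry only a hydroxy, a nitrile or the sulfur-bearing group, so it remains open whether an amine or a carboxylic acid on this ring would give a number clearly apart from these. Going by these compounds, the phenoxy group and the rest of the shared core stay constant in all four compounds, so the response of the series to a change at those places is unknown.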